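Swapping a pyridine for a cyclohexylmethyl on a urea

The compounds below may be only part of what the source reports. "The series", "measured", "known", "first", "only" and "open" are said of these compounds alone.

Compound 1 `O=C(Nc1ccc(Oc2ncnc3[nH]ncc23)cc1)c1ccc(Br)cc1` gives 74700 nM in an assay on isolated protein for inhibition of vascular endothelial growth factor receptor 2 (Danio rerio), read by fluorescence and microscopy, with a stated time of 33 h; a higher number here means a weaker inhibitor, a lower number a stronger inhibitor.
Compound 2 `O=C(Nc1ccc(Oc2ncnc3[nH]ncc23)cc1)Nc1cccnc1` reaches only the limit > 100000 nM in this assay.

Compound 2 stands at the limit of > 100000 nM in this assay, at which 1 of the 2 values shown sits, rather than at a number. Within the data shown here, the one measured step, an at least 1.3-fold higher number from compound 1 to compound 2 (0.12 log units; that floor lies within the scatter), is small. Compound 3 `O=C(NCC1CCCCC1)Nc1ccc(Oc2ncnc3[nH]ncc23)cc1` carries cyclohexylmethyl in place of pyridin-3-yl on an amide-type nitrogen. Among the measured compounds shown here, no measured step touches this change, so no direction beyond the scatter is expected; compound 3 is estimated to stay near the limit. The expected step is a number no higher from compound 2 to compound 3 (the limit leaves the size open). The estimate for compound 3 is 100000 nM, between 30000 nM and 300000 nM.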

Compound 3, half-maximal inhibitory concentration: > 100000 nM
Compound 3 was reported as a limit; the forecaster's own chance of this, stated with the estimate: 65%; the middle value lies on the limit itself.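

In this assay compound 3 gives > 100000 nM, which is a limit and not a number. Among these compounds, replacing the aromatic pyridin-3-yl with the non-aromatic, all-carbon cyclohexylmethyl therefore still gives no measured number, so the step between these two ureas cannot be read, and the only readable step is an at least 1.3-fold higher number from compound 1 to compound 3 (0.12 log units; that floor lies within the scatter). Two quite different groups on this amide-type nitrogen now end at the same point: the limit of > 100000 nM in this assay, at which 2 of the 3 values shown sit.

From the compounds shown here alone, it remains open whether any urea of this kind can give a measured number. A simple methyl or a chain ending in an amine on this nitrogen might show that.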